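Working notes: compound 2 to compound 4

The source may report more compounds than this note shows. Statements on the series, on what has been measured and on what is new or still open speak of the compounds shown alone.

- compound 1 `CN1C[C@H](C(=O)Nc2ccc(C#N)cc2)[C@@H](c2ccc(/C=C/C(=O)Nc3ccccc3N)cc2)C1` gives 35 mL/min/kg
- compound 2 `CN1C[C@H](C(=O)Nc2ccc(C3CC3)cc2)[C@@H](c2ccc(/C=C/C(=O)Nc3ccccc3N)cc2)C1` gives 60 mL/min/kg
- compound 3 `CN1C[C@H](C(=O)Nc2ccc(C(F)(F)F)cc2)[C@@H](c2ccc(/C=C/C(=O)Nc3ccccc3N)cc2)C1` gives 23 mL/min/kg

In an in vitro ADME assay on microsomes from liver (Mus musculus) for pharmacokinetics, read by LC-MS, with a stated time of 10 min, tested at 1 uM (on this read-out higher numbers stand for fast clearance and lower numbers for slow clearance), compound 2 gives 60 mL/min/kg with compound 1 within the scatter of it and compound 3 lower beyond the scatter. Compound 4 `COc1cccc(NC(=O)[C@H]2CN(C)C[C@@H]2c2ccc(/C=C/C(=O)Nc3ccccc3N)cc2)c1` follows from 3-methoxyphenyl in place of 4-cyclopropylphenyl on an amide-type nitrogen with 3-methoxyphenyl in place of 4-cyclopropylphenyl on an amide-type nitrogen. Among the measured compounds shown here, two measured steps bear on this: a 2.6-fold lower number from compound 2 to compound 3 (0.42 log units; beyond the scatter) also removes cyclopropyl and is modest, while a 1.7-fold higher number from compound 1 to compound 2 (0.23 log units; within the scatter) stays within the scatter. For the measured compounds named here, no measured compound carries methoxy, so only a small move to a lower number is expected in this assay and none clearly beyond the scatter. The estimated step is a 1.5-fold lower number from compound 2 to compound 4 (0.18 log units; within the scatter) and no larger one is expected. Compound 4 is expected at 40 mL/min/kg with an estimated range of 22 mL/min/kg to 70 mL/min/kg for the measurement.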

Compound 4, clearance: 65 mL/min/kg
Beside the measured number, compound 4's estimate is 1.6-fold (0.21 log units) below it, within the range that was stated.
By their numbers in this assay, from the lowest: compounds 3, 1, 2 and 4 (each within the scatter of the next, the first and the last beyond it).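

At the amide-type nitrogen, 3-methoxyphenyl in place of 4-cyclopropylphenyl gives no separation in this assay: the result is a 1.1-fold higher number from compound 2 to compound 4 (0.03 log units; within the scatter) and, against the nitrile, a 1.9-fold higher number from compound 1 to compound 4 (0.27 log units; within the scatter) and both lie within the scatter. Against 4-(trifluoromethyl)phenyl the same group gives a 2.8-fold higher number from compound 3 to compound 4 (0.45 log units; beyond the scatter) and this modest step is the only new one beyond the scatter. No measurement at hand accounts for these numbers.

Compound 4 alters both the substituent and where it sits on the phenyl ring, so the two contributions remain unseparated. Going by these compounds, how an amine or a carboxylic acid on that phenyl ring would read in this clearance measurement remains open.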